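Naphthalenyl for formylphenyl on the imidazopyrazine series

A few compounds are considered here, and "the series" means these few. Any claim that something is new, unique, unknown or untested is made for them only; others in the source may bear on it.

Measured compounds:
- compound 1 `c1ccc2c(-c3cn4ccnc4c(-c4ccc5ncn(C6CCCCC6)c5c4)n3)cccc2c1`: 17.5%
- compound 2 `CCc1ccc(-c2cn3ccnc3c(-c3ccc4ncn(Cc5ccccc5)c4c3)n2)cc1`: 49.7%
- compound 3 `O=Cc1ccc(-c2cn3ccnc3c(-c3ccc4ncn(Cc5ccccc5)c4c3)n2)cc1`: 77.9%

In a functional assay on CCRF-CEM cells (Homo sapiens) for inhibition, read by sulforhodamine B assay, with a stated time of 48 h, tested at 10 uM (on this read-out higher numbers stand for more inhibition at the one concentration tested (going by the name of the read-out) and lower numbers for less inhibition), compound 3 gives 77.9%, the highest of the three numbers; the nearest is compound 2 with 49.7% and the furthest is compound 1 with 17.5%. For the measured compounds named here, the one single-point step measured so far, a number 28.2 percentage points higher from compound 2 to compound 3 (beyond the scatter), shows that a formyl group on the pendant aryl ring carries a modest gain over an ethyl group.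

Compound 4 `c1ccc(Cn2cnc3ccc(-c4nc(-c5cccc6ccccc56)cn5ccnc45)cc32)cc1` differs from compound 3 by naphthalen-1-yl in place of 4-formylphenyl on an aromatic carbon. This change removes the formyl group that distinguished compound 3 from compound 2, and it introduces the naphthalen-1-yl group that compound 1 also carries; compound 1, which differs further in the group on the benzimidazole nitrogen, has the lowest of the three numbers. A drop in this assay is therefore expected for compound 4, of the order of a number 42.9 percentage points lower from compound 3 to compound 4 (beyond the scatter), a loss beyond the scatter. Compound 4 is estimated at 35%, with a range from 15% to 58%.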

Compound 4, a percentage reported as inhibition, at one concentration (the size of the read-out at that concentration, not a potency): 6.22%
Beside the measured number, compound 4's estimate is 28.8 percentage points above it; the whole stated range lies above it.
By their numbers in this assay, from the lowest: compound 4; then compound 1; then compound 2; then compound 3.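

In this assay this aromatic carbon of the shared core accepts naphthalen-1-yl far less well than either substituted phenyl, with a number 71.7 percentage points lower from compound 3 to compound 4 (beyond the scatter) and a number 43.5 percentage points lower from compound 2 to compound 4 (beyond the scatter), both large, so the loss is not confined to the departure of the formyl group. With naphthalen-1-yl held fixed, the group on the aromatic nitrogen also shifts the read-out, though less, as a number 11.3 percentage points lower from compound 1 to compound 4 (beyond the scatter) is modest and benzyl gives no advantage over cyclohexyl in this setting. No measurement available here bears on the origin of these drops.

Going by these compounds, whether the loss follows from the second aromatic ring or from the absence of a substituent on the phenyl stays open, and an unsubstituted phenyl would help separate the two. Also open, on these data alone, is whether a carboxylic acid or an amine in place of the formyl group would hold the level of compound 3 .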